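Trimming the Amide Substituent of Compound 1

The compounds below may be only part of what the source reports. "The series", "measured", "known", "first", "only" and "open" are said of these compounds alone.

Compound 1, `CCN(CC)S(=O)(=O)c1ccc(S(=O)(=O)N2CCC[C@@H](C(=O)N[C@@H]3CCN(C(=O)OC(C)(C)C)C3)C2)cc1`, was tested in a functional assay on MIA PaCa-2 cells (Homo sapiens) for inhibition, read by MTT assay, with a stated time of 3 days (on this read-out lower numbers stand for stronger inhibition and higher numbers for weaker inhibition), where compound 1 gives 500 nM. Among the three measured compounds this places compound 1 second highest. The nearest is compound 3, `CCOC(=O)[C@@H]1CCCN(S(=O)(=O)c2ccc(S(=O)(=O)N(CC)CC)c(F)c2)C1`, which in this assay gives 200 nM, a lower number beyond the scatter. The furthest is compound 2, `CCOC(=O)[C@@H]1CCC[C@@H](S(=O)(=O)c2ccc(S(=O)(=O)N(CC)CC)cc2)C1`, which in this assay gives 5000 nM, a higher number also beyond the scatter. For the measured compounds named here, no pair of measured compounds differs in a single place, so the comparison rests on the values alone.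

Compound 4, `CCN(CC)S(=O)(=O)c1ccc(S(=O)(=O)N2CCC[C@@H](C(=O)NC3COC3)C2)cc1`, differs from compound 1 in one place: oxetan-3-yl in place of 1-(tert-butoxycarbonyl)pyrrolidin-3-yl on an amide-type nitrogen. Going by the values given here, the group that leaves is the larger of the two by the count given, and no measured pair shows the effect of such an exchange. The account therefore expects a modest shift toward a higher number, with wide uncertainty. The estimated step is a 2.4-fold higher number from compound 1 to compound 4 (0.38 log units; beyond the scatter) in this assay. Compound 4 is expected to give about 1200 nM, within a range from 300 nM to 5000 nM.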

Compound 4, half-maximal inhibitory concentration: 900 nM
Compound 4: the middle estimate sits 1.3-fold (0.12 log units) above what was measured; low and high end bracket the measured number.
By their numbers in this assay, from the lowest: compound 3; then compounds 1 and 4 (each within the scatter of the next); then compound 2.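

The step of a 1.8-fold higher number from compound 1 to compound 4 (0.26 log units; within the scatter) is the only single-place comparison among these compounds, and it shows that in this assay 1-(tert-butoxycarbonyl)pyrrolidin-3-yl on the amide-type nitrogen can give way to oxetan-3-yl without a change beyond the scatter. At this position, then, the read-out tolerates a drop from 12 heavy atoms to 4, along with the loss of the group's defined stereocentre and its double bond outside aromatic rings. No measurement shown here accounts for why the two groups read alike.

As far as these compounds go, whether a pyrrolidin-3-yl group carrying a free amine, without the tert-butoxycarbonyl group, would read the same at this position remains open. So does the outcome for an open chain, such as ethyl or 2-methoxyethyl, on the amide-type nitrogen.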